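Alkyl ether variation across three measured analogues

The source may hold more compounds than are shown below. What is called first, only, known or untested is meant among the compounds shown, and "the series" means these compounds.

Measured so far:
compound 1 `CC(CC(C)(C)C)Oc1cccc2cccnc12` — > 2000 nM
compound 2 `Nc1ccc2cccc(OC3CCCCCC3)c2n1` — 137 nM
compound 3 `CC(C)C(C)Oc1cccc2ccc(N)nc12` — 199 nM

In an assay on cells with melanin-concentrating hormone receptor 1 (Homo sapiens) as the target, read by radioligand binding (on this read-out lower numbers stand for stronger inhibition and higher numbers for weaker inhibition), compound 1 gives only a limit, > 2000 nM; this is the limit of > 2000 nM in this assay, at which 1 of the 3 values shown sits. Compound 2 in this assay gives 137 nM. Compound 3 gives 199 nM, which stands as the higher of the two numbers yet sits within the scatter of compound 2, so the two are not told apart.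

Compound 4 `CCCCCOc1cccc2ccc(N)nc12` differs from compound 3 by pentyl in place of 1,2-dimethylpropyl on an oxygen on an aromatic ring. Among the compounds with values here, no step between measured compounds bears on a change at this position. The step from compound 3 to compound 4 in this assay, a 1.5-fold higher number from compound 3 to compound 4 (0.18 log units; within the scatter), is expected to be small, not clearly beyond the scatter in either direction. Compound 4 is estimated at 300 nM, within a range from 100 nM to 1000 nM.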

Compound 4, half-maximal inhibitory concentration: 580 nM
For compound 4 the middle estimate is 1.9-fold (0.29 log units) below the measured one, within the range that was stated.
By their numbers in this assay, from the lowest: compounds 2 and 3 (each within the scatter of the next); then compound 4. At a limit, above all of these: compound 1.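

In this assay, pentyl in place of 1,2-dimethylpropyl on an oxygen on an aromatic ring gives a 2.9-fold higher number from compound 3 to compound 4 (0.46 log units; beyond the scatter). Within the data shown here, this is the first step read at this position, and the two groups hold the same atoms, so how those atoms are joined alone moves the number here, though only for this one pair. Nothing measured here bears on the reason for this step.

Still open, from the compounds shown here alone, is whether a longer chain would move the number further from that of compound 4. A terminal amine or carboxylic acid on the pentyl chain is equally unresolved.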